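Swapping Trifluoromethyl for Methyl on a Shared Core

A few compounds are considered here, and "the series" means these few. Any claim that something is new, unique, unknown or untested is made for them only; others in the source may bear on it.

Measured compounds:
compound 1 `CC1(C)CC2CC(C)(CN2C(=O)c2sc(-c3ccc(S(C)(=O)=O)c([N+](=O)[O-])c3)nc2C(F)(F)F)C1`: 2100 nM
compound 2 `CC1Cc2ccccc2N1C(=O)c1sc(-c2ccc(S(C)(=O)=O)c([N+](=O)[O-])c2)nc1C(F)(F)F`: 5200 nM
compound 3 `CN(Cc1ccccc1)C(=O)c1sc(-c2ccc(S(C)(=O)=O)c([N+](=O)[O-])c2)nc1C(F)(F)F`: 3300 nM

In a functional assay for antagonist activity at thyroid hormone receptor beta (Homo sapiens), read by fluorescence polarization, with a stated time of 3 h (on this read-out lower numbers stand for stronger inhibition and higher numbers for weaker inhibition), compound 1 gives 2100 nM, the lowest of the three numbers. Compound 3 lies close, with a 1.6-fold higher number from compound 1 to compound 3 (0.20 log units; within the scatter), whereas compound 2 stands further off, with a 2.5-fold higher number from compound 1 to compound 2 (0.39 log units; beyond the scatter). Between the other two, a 1.6-fold lower number from compound 2 to compound 3 (0.20 log units; within the scatter).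

Compound 4 `Cc1nc(-c2ccc(S(C)(=O)=O)c([N+](=O)[O-])c2)sc1C(=O)N1CC2(C)CC1CC(C)(C)C2` keeps the amide group of compound 1 and alters the shared core instead: methyl in place of trifluoromethyl on an aromatic carbon. None of the three measured steps bears on this change; all of them exchange the group on the carbonyl carbon and leave the trifluoromethyl in place. Among the compounds with values here, the data therefore give no step of known size to lean on. In the absence of any such guide, compound 4 is expected to sit near compound 1, with a 1.2-fold higher number from compound 1 to compound 4 (0.08 log units; within the scatter) as a step not expected to exceed the scatter, and the uncertainty of this expectation is wide. The estimate for compound 4 in this assay is 2500 nM, with a range from 800 nM to 8000 nM.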

Compound 4, half-maximal inhibitory concentration: 7100 nM
Compound 4: the middle estimate sits 2.8-fold (0.45 log units) below what was measured; low and high end bracket the measured number.
By their numbers in this assay, from the lowest: compounds 1, 3, 2 and 4 (each within the scatter of the next, the first and the last beyond it).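

In this assay there is a 3.4-fold higher number from compound 1 to compound 4 (0.53 log units; beyond the scatter) when methyl replaces trifluoromethyl on the aromatic carbon next to the ring nitrogen, with the amide group of compound 1 unchanged. Within the data shown here, the earlier compounds varied only the group on the carbonyl carbon, so this is the first sign that the shared core itself affects the read-out, and the step lies beyond the scatter, with trifluoromethyl giving the stronger inhibition of the two groups. Nothing in the available evidence accounts for this step.

The compounds shown leave open how an ethyl, a chlorine or a nitrile would read on this aromatic carbon. They also leave open whether the same swap would give a step of like size with the amide groups of compound 2 and compound 3.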